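This account rests on a few compounds, and the source may have more. Where it says the series, first, only, none or still open, it means among the compounds named here.

Measured so far: compound 1 `COC(=O)c1ccc(Cl)cc1OC(=O)COc1cc(O)c2c(=O)cc(-c3ccccc3)oc2c1`, 12400 nM; compound 2 `COC(=O)c1cc(O)ccc1OC(=O)COc1cc(O)c2c(=O)cc(-c3ccccc3)oc2c1`, 29500 nM; compound 3 `COC(=O)c1c(Br)cc(Br)cc1OC(=O)COc1cc(O)c2c(=O)cc(-c3ccccc3)oc2c1`, 45700 nM, all in a functional assay on cells (T-cell, Mus musculus, strain BALB/c) for inhibition, read by MTT assay, with a stated time of 72 h; on this read-out higher numbers stand for weaker inhibition and lower numbers for stronger inhibition.

Compound 2 stands second highest of the three numbers, within the scatter of compound 3 and beyond it from compound 1. Compound 4 `COC(=O)c1c(C)cccc1OC(=O)COc1cc(O)c2c(=O)cc(-c3ccccc3)oc2c1` differs from compound 2 by a group of 11 heavy atoms (9 carbon, 2 oxygen; one six-membered aromatic ring of carbon only) in place of a group of 11 heavy atoms (8 carbon, 3 oxygen; one six-membered aromatic ring of carbon only), on an oxygen next to a carbonyl group. Within the data shown here, the only measured step that bears on this change is a 2.4-fold higher number from compound 1 to compound 2 (0.38 log units; beyond the scatter), in which a chlorine-bearing group gave way to a hydroxyl-bearing one. Compound 4 again removes the hydrogen-bond donor, so a modest move back toward the number of compound 1 is expected, though the entering group matches none measured. Compound 4 is estimated at 18000 nM, with a range from 7000 nM to 45000 nM. The step of a 1.6-fold lower number from compound 2 to compound 4 (0.21 log units; within the scatter) is thus the expected outcome.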

Compound 4, half-maximal inhibitory concentration: 37200 nM
The estimate for compound 4 lay 2.1-fold (0.32 log units) below the measured number; the range from low to high includes it.
By their numbers in this assay, from the lowest: compound 1; then compounds 2, 4 and 3 (each within the scatter of the next).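

In this assay, the group with 0 hydrogen-bond donors in place of the one with 1 gives a 1.3-fold higher number from compound 2 to compound 4 (0.10 log units; within the scatter), so the loss of the donor brings no measurable change at this oxygen next to a carbonyl group. The chlorine-bearing group of compound 1 also has 0 hydrogen-bond donors, yet the step to the new group is a 3.0-fold higher number from compound 1 to compound 4 (0.48 log units; beyond the scatter), so the donor count alone does not follow the numbers across these compounds.

No evidence here explains what sets compound 1 apart. Going by these compounds, how an amine or a carboxylic acid on this group would read remains open.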